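This account rests on a few compounds, and the source may have more. Where it says the series, first, only, none or still open, it means among the compounds named here.

Of the compounds shown here, three have so far been measured in a functional assay on WM 266-4 cells (Homo sapiens) for antiproliferative activity, read by MTT assay, with a stated time of 24 h; on this read-out higher numbers stand for weaker inhibition of growth and lower numbers for stronger inhibition of growth. Compound 1 `Oc1ccccc1C1CC(c2ccc(Cl)c(Cl)c2)=NN1c1ccccc1` gives 1570 nM in this assay. Compound 3 `O=C(c1ccc2c(c1)OCCO2)N1N=C(c2ccc(Br)cc2)CC1c1ccccc1F` gives 750 nM. Compound 2 `c1ccc(N2N=C(c3ccc4c(c3)OCCO4)CC2c2cccc3ccccc23)cc1` reaches only the limit of the assay, > 100000 nM, so no real number is known for it. Among the values shown, compound 2 thus stands apart from compound 1 and compound 3, being the one that sits at the limit of > 100000 nM in this assay, at which 1 of the 3 values shown sits.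

Compound 4 `c1ccc(N2N=C(c3ccc4c(c3)OCCO4)CC2c2ccc3ccccc3c2)cc1` has not yet been measured. It is built from the same atoms as compound 2, joined differently: naphthalen-2-yl in place of naphthalen-1-yl on a saturated ring carbon. The phenyl group and the 2,3-dihydro-1,4-benzodioxin-6-yl group stay where they were; only the way the naphthalen-2-yl group, in place of the naphthalen-1-yl group, attaches to the saturated ring carbon of the five-membered non-aromatic ring with 2 nitrogen is changed.

For the measured compounds named here, no measured pair here differs in one place, so the size of such a step cannot be read from a neighbour. Compound 2 offers only a limit to start from, and a rearrangement of the same atoms is most often a small move. The step from compound 2 to compound 4 is expected to be an at least 1.4-fold lower number from compound 2 to compound 4 (0.15 log units; that floor lies within the scatter), at most a modest gain. Compound 4 is estimated at about 70000 nM, within 15000 nM to 100000 nM.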

Compound 4, concentration for 50% growth inhibition: 13900 nM
Compound 4: the middle estimate sits 5.0-fold (0.70 log units) above what was measured; the measured number lies below the stated range.
By their numbers in this assay, from the lowest: compound 3; then compound 1; then compound 4. At a limit, above all of these: compound 2.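

In this assay, putting naphthalen-2-yl in place of naphthalen-1-yl on the saturated ring carbon gives an at least 7.1-fold lower number from compound 2 to compound 4 (0.85 log units; beyond the scatter). For the compounds shown here, the two groups have the same atoms and the same two aromatic rings, so this is the first sign that the way a group is attached at this carbon, and not only what the group is made of, can show up in growth inhibition. The true size of the step stays unknown, because compound 2 has only a limit and not a real number: the limit of > 100000 nM in this assay, at which 1 of the 4 values shown sits.

As far as these compounds go, it remains open how this saturated ring carbon would respond to a group of another kind, such as a pyridine ring or a phenyl group carrying a carboxylic acid, and whether naphthalen-2-yl would behave the same way on the cores of compound 1 and compound 3. Compound 4 differs from compound 1 and compound 3 in more than one place, so their values cannot show which change matters, and the step above remains the only one that can be read.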